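The source may hold more compounds than are shown below. What is called first, only, known or untested is meant among the compounds shown, and "the series" means these compounds.

Measured so far in an ADME assay on MDBK cells (Bos taurus) for cytotoxicity; a higher number here means that more compound is tolerated, a lower number that less compound is tolerated:
- compound 1 `Fc1cccc(F)c1Cn1c(-c2c(F)cccc2F)nc2ccncc21` gives 99000 nM
- compound 2 `Cc1ccn(Cc2c(F)cccc2F)c2nc(-c3c(F)cccc3F)nc1-2` gives only a limit of the assay, > 100000 nM
- compound 3 `COc1cccc(Cn2ccc3nc(-c4ccccc4)nc-3c2)c1` gives only a limit of the assay, > 100000 nM

Compound 3 stands at the limit of this assay, so its true value is not a number but a bound; the same holds for compound 2, as the limit of > 100000 nM in this assay, at which 2 of the 3 values shown sit, records. Only compound 1 has a numerical value, and that value sits close to the bound of the other two. For the measured compounds named here, no pair of measured compounds differs in a single place, so no measured step in this assay can be quoted.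

Compound 4 `Brc1ccc(Cn2ccc3nc(-c4ccccc4)nc-3c2)cc1` is the next member to be measured. It differs from compound 3 by 4-bromophenyl in place of 3-methoxyphenyl on a saturated chain carbon bound to an aromatic nitrogen. Both groups are single six-membered aromatic carbon rings of similar size hanging off the same saturated chain carbon; the difference lies in the substituent and its position on that ring, and a single hydrogen-bond acceptor is lost.

Going by the values given here, with compound 3 at the limit > 100000 nM and no measured step to guide the direction, the step of an at least 1.1-fold lower number from compound 3 to compound 4 (0.07 log units; that floor lies within the scatter) is expected to be none beyond the scatter, perhaps a slight drop in tolerated concentration. Compound 4 is therefore estimated at 85000 nM, with a range from 35000 nM to 200000 nM.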

Compound 4, half-maximal cytotoxic concentration: 83000 nM
Compound 4: middle estimate off by 1.0-fold (0.01 log units), on the high side, within the range that was stated.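

In this assay, for the compounds shown here, the exchange of 3-methoxyphenyl for 4-bromophenyl on a saturated chain carbon bound to an aromatic nitrogen gives an at least 1.2-fold lower number from compound 3 to compound 4 (0.08 log units; that floor lies within the scatter) as the first step that can be read. Going by these compounds alone, compound 4 gives 83000 nM as a number and not a bound, the first such reading for a change at this place. The step has only a floor and its true size stays unfixed, since compound 3 holds only a limit of the assay: the limit of > 100000 nM in this assay, at which 2 of the 4 values shown sit.

On these data alone, the ring substituent and its position change together in this single step, and the share of each in the reading stays open, as does the question of whether a 3-bromophenyl or a 4-methoxyphenyl would separate them. Also open, as far as these compounds go, is what a more strongly different group on that ring, such as an amine or a carboxylic acid, or a longer chain in place of the saturated chain carbon, would give in this assay against compound 4.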